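This account rests on a few compounds, and the source may have more. Where it says the series, first, only, none or still open, it means among the compounds named here.

Compound 3 `CN1CCC(n2cc(S(=O)(=O)c3cccc(F)c3)c3cccnc32)C1` gives the lowest number of the three in an assay on HeLa cells for displacement of a labelled ligand from 5-hydroxytryptamine receptor 6 (Homo sapiens) (a higher number here means a weaker inhibitor, a lower number a stronger inhibitor), namely 1.4 nM. Compound 1 `O=S(=O)(c1cccc(F)c1)c1cn(C2CCNC2)c2ncccc12` gives 2.7 nM in this assay, and compound 2 `CN1CCC(n2cc(S(=O)(=O)c3ccccc3F)c3cccnc32)C1` gives 5.6 nM. The step of a 1.9-fold lower number from compound 1 to compound 3 (0.29 log units; within the scatter) stays within the scatter, while the step of a 4.0-fold lower number from compound 2 to compound 3 (0.60 log units; beyond the scatter) is modest and beyond it. Compound 4 `CN1CCC(n2cc(S(=O)(=O)c3cccc(Cl)c3)c3cccnc32)C1` is not yet measured; it differs from compound 3 by chloro in place of fluoro on an aromatic carbon. Neither measured step swaps one halogen for another, so nothing here directly covers this change. The estimate for compound 4 therefore rests on compound 3 and its value 1.4 nM, and the step of a 1.1-fold lower number from compound 3 to compound 4 (0.03 log units; within the scatter) is expected to stay within the scatter. Compound 4 is expected to give about 1.3 nM in this assay, in the range 0.5 nM to 3.5 nM.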

Compound 4, inhibition constant: 1.5 nM
For compound 4 the middle estimate is 1.2-fold (0.06 log units) below the measured one; the measured number falls inside the stated range.
By their numbers in this assay, from the lowest: compounds 3, 4 and 1 (each within the scatter of the next); then compound 2.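

In this assay, going by these compounds alone, chloro in place of fluoro on an aromatic carbon, meta to a large group, gives a first look at one halogen swapped for another (a 1.1-fold higher number from compound 3 to compound 4 (0.03 log units; within the scatter)), so the two halogens cannot be told apart at this position. The 3-chlorophenyl group also stays clear of the 2-fluorophenyl group (a 3.7-fold lower number from compound 2 to compound 4 (0.57 log units; beyond the scatter)). Nothing available explains either result. On these data alone, whether a methoxy, a nitrile or an amine in the same place would hold the number in this assay stays open, as does whether chloro behaves alike on the core of compound 1.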